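From 4-Methylbenzyl to 4-Ethylbenzyl: One Small Addition

The source may hold more compounds than are shown below. What is called first, only, known or untested is meant among the compounds shown, and "the series" means these compounds.

Among the measured compounds shown here, only two compounds with the same core have been tested so far in a functional assay on A2780 cells (Homo sapiens) for antiproliferative activity, read by resazurin assay, with a stated time of 72 h; on this read-out lower numbers stand for stronger inhibition and higher numbers for weaker inhibition. Compound 1 `CCCN(C)C(=O)c1cc2c(Cc3ccccc3)n[nH]c2cc1O` reports > 10000 nM, which is a limit of the assay and not a number.

For the measured compounds named here, compound 2 `Cc1ccc(CN(C)C(=O)c2cc3c(Cc4ccccc4)n[nH]c3cc2O)cc1` gives 6900 nM, the only actual number available. Going by the values given here, the one measured step is an at least 1.4-fold lower number from compound 1 to compound 2 (0.16 log units; that floor lies within the scatter), with 4-methylphenyl in place of ethyl on a saturated chain carbon bound to an amide-type nitrogen. It therefore shows no firm gain.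

Compound 3 `CCc1ccc(CN(C)C(=O)c2cc3c(Cc4ccccc4)n[nH]c3cc2O)cc1` differs from compound 2 by one small change, methyl in place of hydrogen on a saturated chain carbon bound to an aromatic carbon, which turns 4-methylbenzyl into 4-ethylbenzyl.

Among the compounds with values here, no measured step tests this exact change, and the one available step was a larger change that stayed within the scatter. The expected result is therefore no shift beyond the scatter, with an estimated 1.3-fold lower number from compound 2 to compound 3 (0.10 log units; within the scatter). For compound 3, the estimated value is 5500 nM, with an expected range from 2500 nM to 10000 nM.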

Compound 3, half-maximal inhibitory concentration: 9400 nM
Estimate against measurement, compound 3: 1.7-fold (0.23 log units) below, within the range that was stated.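

Among the compounds shown here, the extra methyl on a saturated chain carbon bound to an aromatic carbon, which turns 4-methylbenzyl into 4-ethylbenzyl, is the first direct test of this position, and in this assay it gives a 1.4-fold higher number from compound 2 to compound 3 (0.13 log units; within the scatter), so compound 2 and compound 3 cannot be told apart on this read-out. Compound 3 also shows no firm gain over the shorter chain of compound 1, since an at least 1.0-fold lower number from compound 1 to compound 3 (0.02 log units; that floor lies within the scatter) is only a floor and says little about the true size of the step. That floor rests on the value of compound 1, which is a limit of the assay and not a number: the limit of > 10000 nM in this assay, at which 1 of the 3 values shown sits.

For the compounds shown here, with only these compounds, one added methyl at this position is the sole small change tested, and it leaves the number within the usual scatter of repeated measurements. Going by these compounds, whether a longer chain such as butyl, or an amine or a carboxylic acid at the end of the ethyl group, would move the number beyond that scatter stays open, as does whether a change elsewhere on the shared core would do more than any change on this benzyl group.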